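Swapping the Aryl Group on a Cyanoguanidine Relaxant

This account rests on a few compounds, and the source may have more. Where it says the series, first, only, none or still open, it means among the compounds named here.

Compound 1, `CC1(C)Oc2ccc(C#N)cc2[C@@H](NC(=O)NCc2ccccc2)[C@@H]1O`: 5600 nM
Compound 2, `CC1(C)Oc2ccc(C#N)cc2[C@@H](/N=C(\NC#N)Nc2cccc(Cl)c2)[C@@H]1O`: 600 nM

Both compounds share one core and differ only in the group carried by the nitrogen. In a functional assay (aorta) with Rattus norvegicus as the target (on this read-out higher numbers stand for weaker inhibition and lower numbers for stronger inhibition), compound 2 gives the lower of the two numbers, and compound 1 lies beyond the scatter above it. Compound 3 `Cc1ccc(N/C(=N/[C@@H]2c3cc(C#N)ccc3OC(C)(C)[C@H]2O)NC#N)cc1` has not yet been measured. It differs from compound 2 by 4-methylphenyl in place of 3-chlorophenyl on an amine nitrogen. For the measured compounds named here, no measured pair shows a change of this kind, so the step of a 2.0-fold higher number from compound 2 to compound 3 (0.30 log units; within the scatter) is expected to be modest, tilted toward weaker inhibition. Compound 3 is therefore estimated at 1200 nM in this assay, with a range from 400 nM to 4000 nM.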

Compound 3, half-maximal inhibitory concentration: 2700 nM
Compound 3: middle estimate off by 2.3-fold (0.35 log units), on the low side, and the stated range covers the measured number.
By their numbers in this assay, from the lowest: compound 2; then compound 3; then compound 1.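

At this position the aryl group on the amine nitrogen is not interchangeable: in this assay, 4-methylphenyl in place of 3-chlorophenyl gives a 4.5-fold higher number from compound 2 to compound 3 (0.65 log units; beyond the scatter). The two groups have the same heavy-atom count and one carbon-only aromatic ring each, yet the number still moves beyond the scatter. Nothing measured here explains the shift. The swap alters both the substituent and its place on the ring, so the compounds shown cannot separate these two changes. On these data alone, how a methoxy group or a plain phenyl ring would read here also stays open.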